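Methoxy to Hydroxymethyl in a Series Without Readable Numbers

This account rests on a few compounds, and the source may have more. Where it says the series, first, only, none or still open, it means among the compounds named here.

Compound 1 `O=C(CCCCCc1ccc(I)cc1)N1CCOC1=O`: in an assay on HEK293 cells for inhibition of N-acylethanolamine-hydrolyzing acid amidase (Rattus norvegicus), read by LC-MS, with a stated time of 30 min (a higher number here means a weaker inhibitor, a lower number a stronger inhibitor), a limit only, > 20000 nM
Compound 2 `COc1ccc(CCCCCC(=O)N2CCOC2=O)cc1`: in this assay a limit only, > 20000 nM

Compound 2 stands at the limit of this assay; no number was read for it. Compound 1 likewise gave only a limit. Within the data shown here, the one measured step, a step that the two limits leave unreadable from compound 1 to compound 2, is therefore unreadable in size and direction, and this is the whole of the evidence: the limit of > 20000 nM in this assay, at which 2 of the 2 values shown sit.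

Compound 3 `O=C(CCCCCc1ccc(CO)cc1)N1CCOC1=O` differs from compound 2 by hydroxymethyl in place of methoxy on an aromatic carbon. Among the measured compounds shown here, no measured step bears readably on this change, since the only step in the set cannot be sized. What is expected for compound 3 rests on compound 2 sitting at the limit, > 20000 nM, and on the small size of the change: the step that the limit leaves unreadable from compound 2 to compound 3 is expected to be none beyond the scatter, with compound 3 most likely again reported only as a limit. The estimate for compound 3 in this assay is 30000 nM, within a range from 8000 nM to 100000 nM.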

Compound 3, half-maximal inhibitory concentration: 190 nM
The estimate for compound 3 lay 160-fold (2.20 log units) above the measured number, outside the stated range (below it).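

In this assay, the aromatic carbon para to a large group proves sensitive to what it carries: hydroxymethyl in place of methoxy gives an at least 100-fold lower number from compound 2 to compound 3 (2.02 log units; beyond the scatter), and hydroxymethyl in place of iodo gives an at least 100-fold lower number from compound 1 to compound 3 (2.02 log units; beyond the scatter). The earlier pair could not show this, as the step between its two limits cannot be read, whereas compound 3 shows that the shared core can give a measured number once this group is changed. The exchange from compound 2 to compound 3 keeps the same atoms, joined differently, with a hydrogen-bond donor entering, and compound 3 alone gives a number rather than a limit: the limit of > 20000 nM in this assay, at which 2 of the 3 values shown sit.

The compounds shown do not tell whether that hydrogen-bond donor or the changed joining of the atoms lies behind the step, and they do not tell how far compound 1 and compound 2 lie beyond their limits. Going by these compounds, how a carboxylic acid, an amine or a longer chain such as hydroxyethyl would read at this place in this assay also remains open.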